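A few compounds are considered here, and "the series" means these few. Any claim that something is new, unique, unknown or untested is made for them only; others in the source may bear on it.

Compound 1: `CC(C)[C@H](C(=O)Nc1ncc(C#N)s1)c1ccc(Cl)cc1`, 2000 nM in a functional assay on CHO cells for agonist activity at Free fatty acid receptor 2 (Homo sapiens), read by cAMP accumulation; a lower number here means a stronger inhibitor, a higher number a weaker inhibitor.
Compound 2: `CC(C)(C)[C@H](C(=O)Nc1ncc(F)s1)c1ccc(Cl)cc1`, 700 nM in this assay.

Of the two measured compounds, compound 2 gives the lower number, and the gap to compound 1 lies beyond the scatter of repeated measurements. Compound 3, `CN(C)c1cnc(NC(=O)[C@H](c2ccc(Cl)cc2)C(C)(C)C)s1`, differs from compound 2 by dimethylamino in place of fluoro on an aromatic carbon, a dimethylamino in place of fluoro on an aromatic carbon. Among the compounds with values here, no measured pair shows this kind of change, so the expectation rests on compound 2 alone. The step from compound 2 to compound 3 is expected to be small and toward a weaker compound, a 1.7-fold higher number from compound 2 to compound 3 (0.23 log units; within the scatter). Compound 3 is estimated at 1200 nM, within 300 nM to 5000 nM.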

Compound 3, half-maximal inhibitory concentration: 1600 nM
Estimate against measurement, compound 3: 1.3-fold (0.12 log units) below; low and high end bracket the measured number.
By their numbers in this assay, from the lowest: compound 2; then compounds 3 and 1 (each within the scatter of the next).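

Putting dimethylamino in place of fluoro on the aromatic carbon next to the ring sulfur gives a 2.3-fold higher number from compound 2 to compound 3 (0.36 log units; beyond the scatter) in this assay and counts as a modest change. This position therefore still gives a measurable number when a group of three heavy atoms replaces a single fluorine. No measurement here accounts for the rise in the number.

Still open, going by these compounds, is how a smaller amine such as methylamino, or a carboxylic acid, would read on this same carbon. A single step also cannot show whether size or another feature of the group matters most.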